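Swapping an Aryl Ring for an Aminomethylpyridine

This account rests on a few compounds, and the source may have more. Where it says the series, first, only, none or still open, it means among the compounds named here.

Three compounds have been measured:

Compound 1, `O=C(O)Cc1sc(CS(=O)(=O)c2ccc(Cl)cc2)nc1-c1ccc(Cl)cc1`: 730 nM
Compound 2, `O=C(O)Cc1sc(C(c2ccccc2)c2ccc(O)cc2)nc1-c1ccc(F)cc1`: 30 nM
Compound 3, `O=C(O)Cc1sc(C(c2ccc(F)cc2)c2ccc(F)cc2)nc1-c1cccc(F)c1`: 18 nM

All three were tested in an in vitro functional assay on HEK285-7 cells for antagonist activity at prostaglandin D2 receptor 2 (Homo sapiens), read by BRET and beta-arrestin recruitment; a higher number here means a weaker inhibitor, a lower number a stronger inhibitor. Compound 1 gives 730 nM, the highest of the three numbers. Compound 2 gives 30 nM and compound 3 gives 18 nM, the lowest number; compound 2 and compound 3 lie within the scatter of each other, so they cannot be told apart, while compound 1 stands well beyond both.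

Compound 4, `Cc1cc(-c2nc(C(c3ccc(F)cc3)c3ccc(F)cc3)sc2CC(=O)O)cnc1N`, has not yet been measured. It differs from compound 3 in one place:

6-amino-5-methylpyridin-3-yl in place of 3-fluorophenyl on an aromatic carbon

Among the compounds with values here, no measured pair shows this kind of change, so there is no direct guide to its size. With nothing to draw on, the expectation is a modest step toward a higher number in this assay, possibly no larger than the scatter. The step from compound 3 to compound 4 is expected to be a 2.2-fold higher number from compound 3 to compound 4 (0.35 log units; beyond the scatter). Compound 4 is therefore estimated at 40 nM, with a range from 12 nM to 150 nM.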

Compound 4, half-maximal inhibitory concentration: > 100000 nM
Compound 4 was reported as a limit; the forecaster's own chance of this, stated with the estimate: 2%; middle value at least 2500-fold (3.39 log units) away from the limit.
By their numbers in this assay, from the lowest: compounds 3 and 2 (each within the scatter of the next); then compound 1. At a limit, above all of these: compound 4.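

In this assay compound 4 gives > 100000 nM, which is a limit of the assay and not a number. Placing 6-amino-5-methylpyridin-3-yl instead of 3-fluorophenyl on this aromatic carbon, next to the ring nitrogen and next to the ring atom that bears the carboxymethyl group, gives an at least 5500-fold higher number from compound 3 to compound 4 (3.74 log units; beyond the scatter). The earlier compounds shown here differ from one another in several places and say nothing about this position alone, whereas this step shows that a single change of aromatic ring here can take the number out of the measurable range.

The entering group differs from 3-fluorophenyl by a ring nitrogen, an amine and a methyl group all at once, and the compounds shown cannot separate these. A plain pyridin-3-yl ring, or a phenyl ring carrying only an amine or only a methyl group, would tell these parts apart.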